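Amide to acid on two related naphthalene-free cores

The source may hold more compounds than are shown below. What is called first, only, known or untested is meant among the compounds shown, and "the series" means these compounds.

Measured compounds:
- Compound 1 `CNC(=O)/C=C/c1ccncc1-c1ccc2ccccc2c1`: in a functional assay on KB cells (Homo sapiens) for inhibition, read by sulforhodamine B assay, with a stated time of 72 h (on this read-out higher numbers stand for weaker inhibition of growth and lower numbers for stronger inhibition of growth), compound 1 gives > 10000 nM, which is a limit of the assay and not a number.
- Compound 2 `O=C(O)/C=C/c1ccncc1-c1ccc2ccccc2c1`: in this assay compound 2 gives > 10000 nM, again a limit of the assay.
- Compound 3 `CNC(=O)/C=C/c1ccncc1-c1ccc2[nH]ccc2c1`: in this assay compound 3 gives > 10000 nM, also a limit of the assay.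

Compound 1 and compound 2 differ in one place: hydroxy in place of methylamino on a carbonyl carbon. The step that the two limits leave unreadable from compound 1 to compound 2 cannot be read, because of the limit of > 10000 nM in this assay, at which 3 of the 3 values shown sit, so both ends of the step are limits rather than numbers.

Compound 3 carries a different core from compound 1; the difference between the two cores is not broken down here. Compound 4 `O=C(O)/C=C/c1ccncc1-c1ccc2[nH]ccc2c1` is not yet measured. It differs from compound 3 by the same change, at the same place: hydroxy in place of methylamino on a carbonyl carbon.

With both sides of the earlier step sitting at the limit, no size for this change is known. For compound 4 the expected step is a step that the limit leaves unreadable from compound 3 to compound 4, resting on compound 3 at > 10000 nM, so compound 4 is estimated at 20000 nM, with a range from 10000 nM to 100000 nM.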

Compound 4, concentration for 50% growth inhibition: > 10000 nM
Compound 4 was reported as a limit (the forecaster's own chance of this, stated with the estimate: 90%); the middle value is on the limit's open side.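

The change from compound 3 to compound 4 gives no readable step, because both ends are limits of the assay rather than numbers: the limit of > 10000 nM in this assay, at which 4 of the 4 values shown sit.

The compounds shown leave open how large the change from methylcarbamoyl to carboxy is on either core, and how strongly any of the four compounds acts in this assay.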